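The source may report more compounds than this note shows. Statements on the series, on what has been measured and on what is new or still open speak of the compounds shown alone.

Within the data shown here, in a functional assay on MGC-803 cells (Homo sapiens) for inhibition, read by sulforhodamine B assay (a higher number here means a weaker inhibitor, a lower number a stronger inhibitor), two compounds built on the same core have numbers so far. Compound 1 `CCc1ccc(NC2=CC(=O)c3c(nc4n3[C@H]3OC[C@@H](O)[C@H]3OC4)C2=O)cc1` gives 1110 nM, and compound 2 `COc1ccccc1NC1=CC(=O)c2c(nc3n2[C@H]2OC[C@@H](O)[C@H]2OC3)C1=O` gives 1670 nM. Among the measured compounds shown here, compound 2 therefore stands within the scatter of the only other measured compound, and the two cannot be ranked. The next compound, compound 3 `COc1ccc(NC2=CC(=O)c3c(nc4n3[C@H]3OC[C@@H](O)[C@H]3OC4)C2=O)cc1`, has not yet been measured. It differs from compound 2 as follows: 4-methoxyphenyl in place of 2-methoxyphenyl on an amine nitrogen. In words, it carries 4-methoxyphenyl in place of 2-methoxyphenyl on an amine nitrogen. For the measured compounds named here, only one measured step bears on this change, and it does so indirectly. That step, a 1.5-fold higher number from compound 1 to compound 2 (0.18 log units; within the scatter), exchanged 4-ethylphenyl for 2-methoxyphenyl on the same nitrogen. Going by the values given here, no measured pair isolates the change from 2-methoxyphenyl to 4-methoxyphenyl, so the data give no firm direction. Among the compounds with values here, with the one step at this nitrogen staying within the scatter, no change beyond the scatter is expected here. The estimated step is a 1.3-fold lower number from compound 2 to compound 3 (0.11 log units; within the scatter), a small one that is expected to stay within the scatter. The expected value for compound 3 is 1300 nM, with an estimated range from 550 nM to 3100 nM.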

Compound 3, half-maximal inhibitory concentration: 2150 nM
For compound 3 the middle estimate is 1.7-fold (0.22 log units) below the measured one; the measured number falls inside the stated range.
By their numbers in this assay, from the lowest: compounds 1, 2 and 3 (each within the scatter of the next).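

Moving the methoxy group, with 2-methoxyphenyl giving way to 4-methoxyphenyl on the amine nitrogen, gives in this assay a 1.3-fold higher number from compound 2 to compound 3 (0.11 log units; within the scatter) and is the first pair to isolate this exchange, which stays within the scatter. The exchange of ethyl for methoxy on an aromatic carbon, with the group held in the same place on the ring, gives a 1.9-fold higher number from compound 1 to compound 3 (0.29 log units; within the scatter) and also stays within the scatter, so none of the three compounds can be separated from the others by these numbers, and neither the place of the methoxy group nor the choice between methoxy and ethyl has yet shown a measurable effect on this nitrogen's aryl group. Nothing available accounts for how small these steps are.

The compounds shown leave open whether a carboxylic acid or an amine in place of the methoxy group, or a longer chain in place of the ethyl group, would carry the number beyond the scatter. Every compound shown also keeps a substituted phenyl on the amine nitrogen, so the effect of an unsubstituted phenyl or of a simple methyl group there remains unknown.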